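A few compounds are considered here, and "the series" means these few. Any claim that something is new, unique, unknown or untested is made for them only; others in the source may bear on it.

Among the measured compounds shown here, in an ADME assay on microsomes from liver (Mus musculus, strain ICR) for metabolic stability, read by LC-MS, using NADPH, with a stated time of 60 min, tested at 0.1 uM (on this read-out higher numbers stand for a more stable compound and lower numbers for a less stable compound), compound 2 (`CC#CCn1c(N2CCC[C@@H](N)C2)cc(=O)n(Cc2ccc(F)c(C(=O)OC)c2)c1=O`) gives 56% as the higher of the two numbers so far, and compound 1 (`CC#CCn1c(N2CCC[C@@H](N)C2)cc(=O)n(Cc2ccc(Br)c(C(=O)OC)c2)c1=O`) gives 38.1% as the lower. Compound 3 (`CC#CCn1c(N2CCC[C@@H](N)C2)cc(=O)n(Cc2ccc(Cl)c(C(=O)OC)c2)c1=O`) is still unmeasured and differs from compound 2 by one change (chloro in place of fluoro on an aromatic carbon), chloro in place of fluoro on an aromatic carbon. For the measured compounds named here, the only measured step bearing on this is a number 17.9 percentage points higher from compound 1 to compound 2 (beyond the scatter) with fluoro in place of bromo on an aromatic carbon. Going from fluoro to chloro is therefore expected to give back part of that step. The expected outcome is a number 11 percentage points lower from compound 2 to compound 3 (beyond the scatter) in this assay here. Compound 3 is estimated at 45% with an expected range from 33% to 57% on this read-out.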

Compound 3, percent of the compound remaining: 34.4%
The estimate for compound 3 lay 10.6 percentage points above the measured number; the measured number falls inside the stated range.
By their numbers in this assay, from the lowest: compounds 3 and 1 (each within the scatter of the next); then compound 2.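

In this assay this position now carries three halogens, and fluoro stands apart: chloro in its place gives a number 21.6 percentage points lower from compound 2 to compound 3 (beyond the scatter) at this one carbon. Chloro in place of bromo gives a number 3.7 percentage points lower from compound 1 to compound 3 (within the scatter) and so does not separate these two halogens. The earlier pair could not show that chloro already sits with bromo rather than partway towards fluoro.

From the compounds shown here alone, whether a plain hydrogen, a methoxy group or a nitrile at this carbon would match fluoro or the other two halogens stays open. Nothing measured here explains why fluoro stands apart.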